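This account rests on a few compounds, and the source may have more. Where it says the series, first, only, none or still open, it means among the compounds named here.

Measured so far:
Compound 1 `CC(C)C(C#Cc1cccc(C(=O)NCc2ccccc2C(F)(F)F)c1)N(O)C(N)=O` gives 500 nM in an assay for inhibition of Polyunsaturated fatty acid 5-lipoxygenase (Homo sapiens), read by HPLC, with stated times of 15 min and 10 min; a higher number here means a weaker inhibitor, a lower number a stronger inhibitor.
Compound 2 `CCC(C#Cc1cccc(C(=O)NCc2ccccc2C(F)(F)F)c1)N(O)C(N)=O` gives 500 nM in this assay.

Compound 2 stands level with compound 1: the step of no change at the digits printed from compound 1 to compound 2 (within the scatter) stays within the usual scatter. Compound 3 `NC(=O)N(O)CC#Cc1cccc(C(=O)NCc2ccccc2C(F)(F)F)c1` has not yet been measured. It differs from compound 2 by hydrogen in place of ethyl on a saturated chain carbon bound to an amide-type nitrogen and a triple-bonded carbon. Within the data shown here, the only measured step that bears on this change is the one from compound 1 to compound 2, which shortened the same branch by one carbon and gave no change at the digits printed from compound 1 to compound 2 (within the scatter). Among the measured compounds shown here, removing the branch altogether is a larger change than that trimming, and no measured compound shows what a bare carbon in this place does, so the expectation rests on that single step and on the size of the change. Compound 3 is therefore expected to give 1000 nM in this assay, with a range from 300 nM to 4000 nM. The expected step is a 2.0-fold higher number from compound 2 to compound 3 (0.30 log units; within the scatter), a modest weakening that could still fall within the scatter.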

Compound 3, half-maximal inhibitory concentration: 4000 nM
Beside the measured number, compound 3's estimate is 4.0-fold (0.60 log units) below it, within the range that was stated.
By their numbers in this assay, from the lowest: compounds 1 and 2 (each within the scatter of the next); then compound 3.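

At the saturated chain carbon bound to an amide-type nitrogen and a triple-bonded carbon, the presence of a branch does matter in this assay: replacing ethyl with hydrogen gives an 8.0-fold higher number from compound 2 to compound 3 (0.90 log units; beyond the scatter), and replacing isopropyl with hydrogen gives an 8.0-fold higher number from compound 1 to compound 3 (0.90 log units; beyond the scatter). Compound 1 and compound 2 could not be told apart, so among these three compounds the change beyond the scatter appears only with the bare carbon of compound 3. Nothing measured here accounts for this loss.

On these data alone, it remains open whether a single methyl at this carbon would behave like ethyl or like hydrogen. A longer chain, such as butyl, or a cyclopropyl ring at this carbon also leaves open how far the number holds once the branch grows beyond isopropyl.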